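The source may hold more compounds than are shown below. What is called first, only, known or untested is meant among the compounds shown, and "the series" means these compounds.

Compound 1 `CCCSc1nnc(Cc2ccccc2Oc2ccccc2)[nH]1` in a functional assay on the whole organism (strain NMRI) with Mus musculus as the target, with a stated time of 60 min, at a dose of 20 mg/kg by the intraperitoneal route (on this read-out higher numbers stand for a stronger effect at the one dose given and lower numbers for a weaker effect), gives 158%. Compound 2 `c1ccc(CSc2nnc(Cc3ccccc3Oc3ccccc3)[nH]2)cc1` gives 143%. Compound 3 `CCCSc1nnc(Cc2ccc(Cl)cc2Oc2ccccc2F)[nH]1` gives 133%.

Compounds 1 and 2 share a core and differ in a single place: phenyl in place of ethyl on a saturated chain carbon bound to a sulfur. That change made a number 15 percentage points lower from compound 1 to compound 2 (beyond the scatter). Compound 3 carries a different core, and the difference between the two cores is not broken down here; its value in this assay simply stands where it does beside the other two. Compound 4 `Fc1ccccc1Oc1cc(Cl)ccc1Cc1nnc(SCc2ccccc2)[nH]1` has not yet been measured. It stands to compound 3 as compound 2 stands to compound 1, with the same change in the same place: phenyl in place of ethyl on a saturated chain carbon bound to a sulfur. This change occurs twice among the four compounds, and only one of the two instances has been measured, so any expectation for compound 4 rests on a single step. Because a number 15 percentage points lower from compound 1 to compound 2 (beyond the scatter) was modest and beyond the scatter, a step of about the same size is expected for compound 4. For compound 4 the estimate in this assay is 118%, expected to lie between 95% and 140%. This estimate means an expected step of a number 15 percentage points lower from compound 3 to compound 4 (beyond the scatter).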

Compound 4, a percentage reported as activity, at one dose (the size of the read-out at that dose, not a potency): 179%
For compound 4 the middle estimate is 61 percentage points below the measured one, outside the stated range (above it).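

On the core of compound 3, phenyl in place of ethyl on a saturated chain carbon bound to a sulfur, which turns propylsulfanyl into benzylsulfanyl, gives a number 46 percentage points higher from compound 3 to compound 4 (beyond the scatter) in this assay. For the compounds shown here, in this series, the effect of the change does not carry over from one core to the other, not even in its direction, as the two steps show: the same change on two cores in this assay, a number 15 percentage points lower (beyond the scatter) from compound 1 to compound 2 and a number 46 percentage points higher (beyond the scatter) from compound 3 to compound 4, 61 percentage points apart, beyond the scatter of two such steps What this does not show is which difference between the two cores goes with the reversal, or how the change would behave on any further core, as each core offers only one pair.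

From the compounds shown here alone, it remains open what a longer chain such as butyl, or a chain ending in an amine, would do in this place on either core. Also open, going by these compounds, is whether the chlorine or the fluorine of compound 3, taken alone, would be enough to turn the step around.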